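The compounds below may be only part of what the source reports. "The series", "measured", "known", "first", "only" and "open" are said of these compounds alone.

Working notes on the series. Compound 1 `CCN/C(SC)=C(/C#N)C(=O)Nc1ccc(OCC)cc1` has an open-chain core; in a functional assay on Huh-7 cells (Homo sapiens) for cytotoxicity, read by resazurin assay, with a stated time of 48 h (on this read-out higher numbers stand for weaker inhibition and lower numbers for stronger inhibition), compound 1 gives 16400 nM. Compound 2 `C=CCN/C(SC)=C(/C#N)C(=O)Nc1ccc(OCC)cc1` differs from compound 1 by vinyl in place of methyl on a saturated chain carbon bound to an amine nitrogen, and in this assay compound 2 gives 8850 nM. Within the data shown here, the measured step here is a 1.9-fold lower number from compound 1 to compound 2 (0.27 log units; within the scatter), the only measured instance of this change in the set. Compound 3 `CCNc1[nH]nc2nnn(-c3ccc(OCC)cc3)c(=O)c12` carries a different, fused core; the difference between the two cores is not broken down here. In this assay compound 3 gives 14400 nM, a number within the scatter of both compound 1 and compound 2, so no order among the three can be read.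

Compound 4 `C=CCNc1[nH]nc2nnn(-c3ccc(OCC)cc3)c(=O)c12` has not yet been measured. It differs from compound 3 by vinyl in place of methyl on a saturated chain carbon bound to a nitrogen on an aromatic ring. This is the same kind of change as that between compound 1 and compound 2, not the same one: in the measured pair the carbon is bound to an amine nitrogen, whereas in compound 3 it is bound to a nitrogen on an aromatic ring. Among the measured compounds shown here, only one measured pair is available and it sits on a different core, so the expectation is loose. The step expected is a 1.7-fold lower number from compound 3 to compound 4 (0.23 log units; within the scatter), set beside the earlier 1.9-fold lower number from compound 1 to compound 2 (0.27 log units; within the scatter), and it rests on that single pair and on compound 3 at 14400 nM. For compound 4 the estimate in this assay is 8500 nM, expected to fall between 4000 nM and 20000 nM.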

Compound 4, half-maximal inhibitory concentration: 4940 nM
The estimate for compound 4 lay 1.7-fold (0.24 log units) above the measured number; measured number inside the range.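

In this assay, the change from ethylamino to allylamino on the fused core gives a 2.9-fold lower number from compound 3 to compound 4 (0.46 log units; beyond the scatter). Set beside the same kind of change on the open-chain core, the two steps cannot be told apart: the same change on two cores in this assay, a 1.9-fold lower number (0.27 log units; within the scatter) from compound 1 to compound 2 and a 2.9-fold lower number (0.46 log units; beyond the scatter) from compound 3 to compound 4, 1.6-fold (0.20 log units) apart, within the scatter of two such steps This fits a change that carries from one core to the other with a similar size, but it rests on only two pairs, and the step on the open-chain core does not by itself clear the scatter, so it shows neither a firm gain on both cores nor a larger gain on the fused core.

The compounds shown leave open whether the lower number on the fused core goes with the double bond of the allyl group or simply with the longer chain, a question that a propyl group on the same nitrogen would address. Also open, from the compounds shown here alone, is how far the step extends to other groups at this place, such as propargyl, cyclopropylmethyl or butyl, and whether it holds when the ethoxy group on the phenyl ring is replaced by another group, such as methoxy or chloro.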